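This account rests on a few compounds, and the source may have more. Where it says the series, first, only, none or still open, it means among the compounds named here.

Measured compounds:
compound 1, `Cc1ccc(-c2nc(C(F)(F)F)n(CC[C@@H](O)C[C@@H](O)CC(=O)O)c2-c2ccc(F)cc2)cc1`, 43 nM
compound 2, `O=C(O)C[C@H](O)C[C@H](O)CCn1c(C(F)(F)F)nc(-c2ccc(C(F)(F)F)cc2)c1-c1ccc(F)cc1`, 200 nM
compound 3, `Cc1ccc(-c2c(-c3ccc(F)cc3)nc(C(F)(F)F)n2CC[C@@H](O)C[C@@H](O)CC(=O)O)cc1`, 750 nM

All three numbers come from an assay on microsomes from liver for inhibition of 3-hydroxy-3-methylglutaryl-coenzyme A reductase (Rattus norvegicus); a lower number here means a stronger inhibitor, a higher number a weaker inhibitor. In this assay compound 1 gives 43 nM and compound 2 gives 200 nM, the two differing by trifluoromethyl in place of methyl on an aromatic carbon; the resulting step is a 4.7-fold higher number from compound 1 to compound 2 (0.67 log units; beyond the scatter). Compound 3 carries the same atoms as compound 1, joined differently, and the difference between the two cores is not broken down here. Compound 3 gives 750 nM, the highest of the three numbers; set against compound 2 and compound 1, its values show it to be a weaker inhibitor than either.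

Compound 4, `O=C(O)C[C@H](O)C[C@H](O)CCn1c(C(F)(F)F)nc(-c2ccc(F)cc2)c1-c1ccc(C(F)(F)F)cc1`, has not yet been measured. It differs from compound 3 by trifluoromethyl in place of methyl on an aromatic carbon. This is the same change that leads from compound 1 to compound 2, made on the core of compound 3 instead. Since the earlier step, a 4.7-fold higher number from compound 1 to compound 2 (0.67 log units; beyond the scatter), raised the number well beyond the scatter, the expectation for compound 4 is a step in the same direction, a 3.7-fold higher number from compound 3 to compound 4 (0.57 log units; beyond the scatter), set beside the earlier one; the core differs, so the size is held loosely. On that basis compound 4 is estimated at 2800 nM in this assay, expected to lie between 800 nM and 9000 nM.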

Compound 4, half-maximal inhibitory concentration: > 1000 nM
Compound 4: only a limit was reported; the forecaster's own chance of this, stated with the estimate: 10%; the middle value does not contradict the limit.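

In this assay compound 4 is reported only as a limit of the assay, not as a number: the limit of > 1000 nM in this assay, at which 1 of the 4 values shown sits.

On the core of compound 3, the change from 4-methylphenyl to 4-(trifluoromethyl)phenyl therefore gives only a floor, an at least 1.3-fold higher number from compound 3 to compound 4 (0.12 log units; that floor lies within the scatter), and that floor alone does not establish a shift beyond the scatter, although it fits a step in the same direction as the one on the core of compound 1, a 4.7-fold higher number from compound 1 to compound 2 (0.67 log units; beyond the scatter). What this shows is limited: no reversal of the change is seen on the second core, but neither a matching size nor a different size can be claimed, so the change cannot yet be said to carry over from one core to the other with a fixed size, and the two steps stand as follows: the same change on two cores in this assay, a 4.7-fold higher number (0.67 log units; beyond the scatter) from compound 1 to compound 2 and an at least 1.3-fold higher number (0.12 log units; that floor lies within the scatter) from compound 3 to compound 4; the limit leaves it open whether they differ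

The compounds shown leave open how a nitrile, a chlorine or a methoxy group would read in place of methyl or trifluoromethyl at this position on either core. They also leave open whether the same change would behave alike with an ester or an amide in place of the carboxylic acid, or with a longer chain joining the core to the dihydroxy acid.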